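Trifluoromethyl in place of methylcarbamoyl on compound 3

The source may hold more compounds than are shown below. What is called first, only, known or untested is meant among the compounds shown, and "the series" means these compounds.

In a physicochemical assay for solubility, with a stated time of 4 h, at pH 7.4 (a higher number here means a more soluble compound, a lower number a less soluble compound), compound 3 `CNC(=O)c1cc(N)c(Nc2ccc(C#N)cc2)cc1Oc1c(C)cc(CCC#N)cc1C` gives 8.28 ug/mL and holds the highest of three numbers. Compound 1 `Cc1cc(/C=C/C#N)cc(C)c1Oc1cc(Nc2ccc(C#N)cc2)c(N)cc1C(N)=O` gives 0.63 ug/mL and compound 2 `CC(=O)CCc1cc(C)c(Oc2cc(Nc3ccc(C#N)cc3)c(N)cc2C(F)(F)F)c(C)c1` gives 0.16 ug/mL in the same measurement. The gaps from both of them to compound 3 lie beyond the scatter.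

Compound 4 `Cc1cc(CCC#N)cc(C)c1Oc1cc(Nc2ccc(C#N)cc2)c(N)cc1C(F)(F)F` follows from compound 3 with trifluoromethyl in place of methylcarbamoyl on an aromatic carbon and with the rest of the structure unchanged.

Among the measured compounds shown here, no two measured compounds differ in one place only, so the size of this step has no direct precedent. The nearest guide is compound 2 with 0.16 ug/mL as its number, which also carries trifluoromethyl on that aromatic carbon but differs from compound 4 in another place. On that basis a clear fall beyond the scatter in this assay is expected.

The estimated step runs a 24-fold lower number from compound 3 to compound 4 (1.37 log units; beyond the scatter) and is expected to be downward. For compound 4 the expected value is 0.35 ug/mL (estimated range 0.08 ug/mL to 1.5 ug/mL).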

Compound 4, solubility: 0.24 ug/mL
Compound 4: the middle estimate sits 1.5-fold (0.16 log units) above what was measured; measured number inside the range.
By their numbers in this assay, from the lowest: compounds 2 and 4 (each within the scatter of the next); then compound 1; then compound 3.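

In this assay, among the compounds shown here, this is the first direct comparison at this aromatic carbon: trifluoromethyl in place of methylcarbamoyl gives a 35-fold lower number from compound 3 to compound 4 (1.54 log units; beyond the scatter) and marks a large step at this position. The earlier compounds shown here could not isolate this change, as none of them differed in one place only. With trifluoromethyl held constant, cyano in place of acetyl on a saturated chain carbon, two bonds along the chain from an aromatic carbon, gives a 1.5-fold higher number from compound 2 to compound 4 (0.18 log units; within the scatter), so this chain change does not separate the pair in this assay.

No measurement shown accounts for the large step at the aromatic carbon. Where a carboxylic acid or a dimethylcarbamoyl group at this aromatic carbon would fall relative to methylcarbamoyl and trifluoromethyl in this assay remains open.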